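A few compounds are considered here, and "the series" means these few. Any claim that something is new, unique, unknown or untested is made for them only; others in the source may bear on it.

For the measured compounds named here, compound 2 `O=C(Cn1cc(-c2cccs2)nn1)Nc1nc2ccccc2s1` is the one member of this pair with a number rather than a limit in a functional assay on BMDM cells (Mus musculus, strain C57BL/6) for inhibition, with a stated time of 2 days (on this read-out higher numbers stand for weaker inhibition and lower numbers for stronger inhibition), where compound 2 gives 21400 nM. Compound 1 `N#Cc1ccc(-c2cn(CC(=O)Nc3nc4ccccc4s3)nn2)cc1` reaches only the limit of this assay, with compound 1 at > 30000 nM; that limit is the evidence the limit of > 30000 nM in this assay, at which 1 of the 2 values shown sits, for how much of the series sits at the ceiling. Going by the values given here, the single measured step, an at least 1.4-fold lower number from compound 1 to compound 2 (0.14 log units; that floor lies within the scatter), is the only guide to swapping the group on this aromatic carbon, and its floor lies within the scatter, so it fixes neither size nor direction firmly.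

Compound 3 `O=C(Cn1cc(-c2ccncc2)nn1)Nc1nc2ccccc2s1` is not yet measured in this assay. The change is pyridin-4-yl in place of thiophen-2-yl on an aromatic carbon. Like the measured step, it exchanges one aromatic ring for another at the same carbon, each carrying one hetero atom and one hydrogen-bond acceptor, with no hydrogen-bond donor and no charge added. Nothing measured points to a shift beyond the scatter in either direction.

Compound 3 is therefore expected near 22000 nM, within 7000 nM to 60000 nM. The expected step of a 1.0-fold higher number from compound 2 to compound 3 (0.01 log units; within the scatter) stays within the scatter, with a real chance that only a limit is reported.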

Compound 3, half-maximal inhibitory concentration: 50 nM
Compound 3: the middle estimate sits 440-fold (2.64 log units) above what was measured, and the stated range ends above it.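

In this assay, the aromatic carbon of the five-membered aromatic ring with 3 nitrogen proves far more sensitive to its group than the first pair could show: pyridin-4-yl in place of thiophen-2-yl gives a 430-fold lower number from compound 2 to compound 3 (2.63 log units; beyond the scatter), with the counts of hydrogen-bond donors and acceptors and the net charge unchanged. Pyridin-4-yl in place of 4-cyanophenyl gives an at least 600-fold lower number from compound 1 to compound 3 (2.77 log units; beyond the scatter), so a six-membered aromatic ring at this carbon does not by itself account for the gain, and the ring nitrogen of pyridin-4-yl becomes the feature to test. Compound 1 gives > 30000 nM, which is a limit and not a number, so the true size of that second step stays unknown because the series reaches the ceiling of the assay: the limit of > 30000 nM in this assay, at which 1 of the 3 values shown sits.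

A plain phenyl, a pyridin-3-yl or a pyridin-2-yl group at this carbon would show whether the gain depends on having a ring nitrogen and on where that nitrogen sits. The compounds shown also leave open whether the pyridin-4-yl ring accepts further groups, such as an amine or a methyl, and why this one exchange has so large an effect.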